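The source may report more compounds than this note shows. Statements on the series, on what has been measured and on what is new or still open speak of the compounds shown alone.

In a physicochemical assay for solubility, read by nephelometry, in phosphate buffer, at pH 7.4 (on this read-out lower numbers stand for lower solubility and higher numbers for higher solubility), compound 1 (`Cc1sc(-c2ccccc2C(N)=O)cc1C(=O)Nc1nc2c(s1)CCC2`) gives 1950 nM and compound 2 (`Cc1sc(C2CCCN2C(=O)CN)cc1C(=O)Nc1nccs1`) gives 7810 nM. Compound 2 thus holds the higher of the two numbers, and its gap to compound 1 lies beyond the usual scatter. The two compounds differ in more than one place, however, so that gap cannot be tied to any single change. Compound 3 (`Cc1sc(C2CCCN2C(=O)CN(C)C)cc1C(=O)Nc1nccs1`) has not yet been measured. It differs from compound 2 in one place: dimethylamino in place of amino on a saturated chain carbon bound to a carbonyl carbon, with dimethylamino in place of amino on a saturated chain carbon bound to a carbonyl carbon. No measured pair isolates this change, and nothing shown sets a direction for it. The expected outcome is therefore no shift beyond the scatter, with an estimated 1.1-fold lower number from compound 2 to compound 3 (0.05 log units; within the scatter). The estimate for compound 3 is 7000 nM, expected to fall between 2800 nM and 17000 nM.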

Compound 3, solubility: 7810 nM
The estimate for compound 3 lay 1.1-fold (0.05 log units) below the measured number, within the range that was stated.
By their numbers in this assay, from the lowest: compound 1; then compounds 2 and 3 (each within the scatter of the next).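

In this assay, among these compounds, the swap of amino for dimethylamino on a saturated chain carbon bound to a carbonyl carbon gives no change at the digits printed from compound 2 to compound 3 (within the scatter) and is the only measured change at this position. It takes the count from 1 heavy atom to 3 heavy atoms and from 1 hydrogen-bond donor to 0 hydrogen-bond donors, yet the two compounds stay within the scatter of each other in this assay as this one pair shows. The data shown offer no explanation for this result.

Still open, from the compounds shown here alone, is whether a carboxylic acid, a pyrrolidine or a longer chain at this place would also stay within the scatter. Also open, going by these compounds, is whether the swap of amino for dimethylamino would read the same on the core of compound 1.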